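Swapping a Sulfonamide Arm for a Methoxyphenyl Ring

The source may report more compounds than this note shows. Statements on the series, on what has been measured and on what is new or still open speak of the compounds shown alone.

Compound 2 `Cc1ccc(S(=O)(=O)NCc2cn(C[C@H](O)[C@H]3OC(=O)C(OCc4ccccc4)=C3OCc3ccccc3)nn2)cc1` gives 13100 nM in a functional assay on HCT-116 cells (Homo sapiens) for antiproliferative activity, read by MTT assay, with a stated time of 72 h; on this read-out higher numbers stand for weaker inhibition and lower numbers for stronger inhibition. Of the two numbers shown it sits at the lower end, though its nearest neighbour, compound 3 `O=C1O[C@H]([C@@H](O)Cn2cc(CNS(=O)(=O)c3ccc(Cl)cc3F)nn2)C(OCc2ccccc2)=C1OCc1ccccc1`, lies within the scatter: compound 3 gives 21600 nM in this assay. The step of a 1.6-fold higher number from compound 2 to compound 3 (0.22 log units; within the scatter) comes from a 4-chloro-2-fluorophenyl in place of a 4-methylphenyl on a sulfonyl sulfur. Compound 1 `COc1ccc(-c2cn(C/C=C3\OC(=O)C(OCc4ccccc4)=C3OCc3ccccc3)nn2)cc1` gives only > 100000 nM in this assay, which is a limit of the assay and not a number. One of the three values therefore sits at the limit of > 100000 nM in this assay, at which 1 of the 3 values shown sits.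

Compound 4 `COc1ccc(-c2cn(C[C@H](O)[C@H]3OC(=O)C(OCc4ccccc4)=C3OCc3ccccc3)nn2)cc1` is not yet measured and differs from compound 2 in a single place: 4-methoxyphenyl in place of (((4-methylphenyl)sulfonyl)amino)methyl on an aromatic carbon. Within the data shown here, no measured step covers this exchange. Among the measured compounds shown here, the only step available, the switch on a sulfonyl sulfur from compound 2 to compound 3, stayed within the scatter and says nothing about removing that arm altogether, so no direction can be set with confidence. Compound 4 is therefore expected to give about 20000 nM, within a wide range from 5000 nM to 100000 nM. The estimated step, a 1.5-fold higher number from compound 2 to compound 4 (0.18 log units; within the scatter), is expected to remain modest.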

Compound 4, half-maximal inhibitory concentration: > 100000 nM
Compound 4: a limit, no number; the forecaster's own chance of this, stated with the estimate: 30%; at least 5.0-fold (0.69 log units) between middle value and limit.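

Putting 4-methoxyphenyl in place of (((4-methylphenyl)sulfonyl)amino)methyl on this aromatic carbon gives an at least 7.6-fold higher number from compound 2 to compound 4 (0.88 log units; beyond the scatter) in this assay, so activity at this position depends on the group it carries. Among these compounds, the earlier change on the sulfonyl sulfur, a 1.6-fold higher number from compound 2 to compound 3 (0.22 log units; within the scatter), showed only that one ring on the sulfur could replace another without a clear change in the reading; replacing the whole arm is the first change here, among compounds that differ in one place, to go beyond the scatter. Compound 4 gives a limit of the assay and not a number, so the step shows only a minimum size, and the true size remains unknown: the limit of > 100000 nM in this assay, at which 2 of the 4 values shown sit.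

The exchange removes the sulfonyl group, the amino link and the methyl carbon of the arm in one move, so the compounds shown cannot tell which of these parts matters, or whether the entering 4-methoxyphenyl ring itself plays a part. Going by these compounds, whether a plain aminomethyl group or an acetamidomethyl group on the same carbon would keep the activity of compound 2 also remains open.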